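Acetyl to dimethylamino on the pendant phenyl ring

The source may hold more compounds than are shown below. What is called first, only, known or untested is meant among the compounds shown, and "the series" means these compounds.

compound 1 `COc1cc(C)cc(-c2c(-c3ccnc(-c4ccc(C(C)=O)cc4)c3)cnn2CC#N)c1`: in a functional assay on HT-29 cells (Homo sapiens) for inhibition, read by sulforhodamine B assay, with a stated time of 48 h (on this read-out higher numbers stand for weaker inhibition of growth and lower numbers for stronger inhibition of growth), compound 1 gives > 100000 nM
compound 2 `COc1cc(C)cc(-c2nn(CC#N)cc2-c2ccc(-c3cccc(C(C)=O)c3)nc2)c1`: in this assay compound 2 gives 18700 nM
compound 3 `Cc1cc(O)cc(-c2nn(CC#N)cc2-c2ccnc(-c3ccc(N(C)C)cc3)c2)c1`: in this assay compound 3 gives 20800 nM

Compound 1 stands at the edge of what this assay reports: its value is a limit, not a number, and the point on the scale is the limit of > 100000 nM in this assay, at which 1 of the 3 values shown sits. Compound 2 and compound 3 each give a number, and those two numbers lie within the usual scatter of each other, so no order between them is claimed.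

Compound 4 `COc1cc(C)cc(-c2c(-c3ccnc(-c4ccc(N(C)C)cc4)c3)cnn2CC#N)c1` is not yet measured. It differs from compound 1 by dimethylamino in place of acetyl on an aromatic carbon. Within the data shown here, no pair of measured compounds shares this exact change, so the size of the step has to be inferred. Compound 3 also carries the dimethylamino group and gives 20800 nM, which is taken as the anchor for the expectation. The step of an at least 3.3-fold lower number from compound 1 to compound 4 (0.52 log units; beyond the scatter) is therefore expected to run toward stronger inhibition of growth, well beyond the scatter. For compound 4 the estimate in this assay is 30000 nM, with a range from 8000 nM to 100000 nM.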

Compound 4, concentration for total growth inhibition: 211 nM
Compound 4: middle estimate off by 140-fold (2.15 log units), on the high side; measured number below the stated range.
By their numbers in this assay, from the lowest: compound 4; then compounds 2 and 3 (each within the scatter of the next). At a limit, above all of these: compound 1.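

In this assay, among these compounds, the change from 4-acetylphenyl to 4-(dimethylamino)phenyl gives the first step between compounds that differ in one place: an at least 470-fold lower number from compound 1 to compound 4 (2.67 log units; beyond the scatter). With the rest of the structure held constant, the group on this aromatic carbon, para to a large group, separates a compound at the limit of the assay from one with a measured value, even though acetyl and dimethylamino match in heavy-atom count and in hydrogen-bond donors and acceptors, so those counts do not tell the two groups apart. The true size of the step remains unknown because compound 1 carries a limit and not a number: the limit of > 100000 nM in this assay, at which 1 of the 4 values shown sits.

As far as these compounds go, whether the step needs dimethylamino itself stays open, since a primary amine, a methoxy group or a pyrrolidine at the same position would show how much of it survives when the group is changed. Among the compounds shown here, only this one pair carries the change, so whether a step of this size recurs on a different core also remains unanswered.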